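The compounds below may be only part of what the source reports. "The series", "measured", "known", "first", "only" and "open" are said of these compounds alone.

Of the compounds shown here, three have so far been measured in a functional assay on CCRF-CEM cells (Homo sapiens) for antiproliferative activity, read by trypan blue exclusion, with a stated time of 72 h; a lower number here means a stronger inhibitor, a higher number a weaker inhibitor. Compound 1 `Cc1ccc(C(=O)NC(N)=O)cc1NC(=O)C(C)Br` gives 3360 nM. Compound 3 `CC(Br)C(=O)Nc1cc(C(=O)NC(N)=O)ccc1F` gives 3130 nM. Compound 2 `Cc1ccc(NC(=O)C(C)Br)cc1C(=O)NC(N)=O` gives > 20000 nM, which is a limit of the assay and not a number.

Compound 1 and compound 3 differ in one place: fluoro in place of methyl on an aromatic carbon. In this assay that change gave a 1.1-fold lower number from compound 1 to compound 3 (0.03 log units; within the scatter). Compound 2 has the same atoms as compound 1, joined differently; how the two cores differ is not broken down here. Compound 4 `CC(Br)C(=O)Nc1ccc(F)c(C(=O)NC(N)=O)c1` has not yet been measured and is made from compound 2 by fluoro in place of methyl on an aromatic carbon. The place is not the same, though: in compound 1 the changed carbon is ortho to the ((1-bromoethyl)carbonyl)amino group and para to the carbamoylcarbamoyl group, whereas in compound 2 it is ortho to the carbamoylcarbamoyl group and para to the ((1-bromoethyl)carbonyl)amino group, so this is the same kind of change, not the same change.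

Because compound 2 sits at the limit of > 20000 nM in this assay, at which 1 of the 3 values shown sits, only a rough expectation is possible. In this assay a small step like a 1.1-fold lower number from compound 1 to compound 3 (0.03 log units; within the scatter) is expected, namely a step that the limit leaves unreadable from compound 2 to compound 4. Compound 4 is therefore estimated at 25000 nM, with an expected range from 10000 nM to 60000 nM, and most likely the assay will again report only a limit.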

Compound 4, half-maximal inhibitory concentration: 520 nM
Compound 4: the middle estimate sits 48-fold (1.68 log units) above what was measured, outside the stated range (below it).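

In this assay compound 2 stands at > 20000 nM, which is a limit of the assay and not a number. Even so, fluoro in place of methyl gave an at least 38-fold lower number from compound 2 to compound 4 (1.58 log units; beyond the scatter), and the size of this change did not carry over from one core to the other: the same change on two cores in this assay, a 1.1-fold lower number (0.03 log units; within the scatter) from compound 1 to compound 3 and an at least 38-fold lower number (1.58 log units; beyond the scatter) from compound 2 to compound 4, at least 35-fold (1.55 log units) apart, beyond the scatter of two such steps

So in this series, the result of this swap depends on the core that carries it, but a single pair on each core does not show why, and the limit hides the full size of the larger step.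

The compounds shown leave open whether a chloro or a methoxy group on the same carbon would behave like fluoro on either core. They also leave open whether the gap between the cores would remain with a longer chain in place of the ((1-bromoethyl)carbonyl)amino group.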